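A Chlorine Shifts Position on the Aryl Ring

The compounds below may be only part of what the source reports. "The series", "measured", "known", "first", "only" and "open" are said of these compounds alone.

Measured compounds:
- compound 1 `Cc1nc2c([nH]1)C(=O)/C(=N/c1ccccc1)C(Cl)=C2O`: 800 nM
- compound 2 `Cc1nc2c([nH]1)C(=O)/C(=N/c1ccc(F)cc1)C(Cl)=C2O`: 3000 nM
- compound 3 `Cc1nc2c([nH]1)C(=O)/C(=N/c1ccc(Cl)cc1)C(Cl)=C2O`: 2800 nM; 2820 nM (2 entries)

All three share one core and differ only in the aryl group on the double-bonded nitrogen. In an ADME assay (Rattus norvegicus) for inhibition (on this read-out lower numbers stand for stronger inhibition and higher numbers for weaker inhibition), compound 2 has the highest of the two single numbers; its nearest neighbour is compound 1, with a 3.8-fold higher number from compound 1 to compound 2 (0.57 log units; beyond the scatter). For the measured compounds named here, compound 3 has several entries, (the several entries of compound 3 in this assay, 2800 nM; 2820 nM (2 entries)), and these lie close to the number of compound 2, although no single step between those two is on record.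

Compound 4 `Cc1nc2c([nH]1)C(=O)/C(=N/c1cccc(Cl)c1)C(Cl)=C2O` differs from compound 2 in one place: 3-chlorophenyl in place of 4-fluorophenyl on a double-bonded nitrogen. Going by the values given here, only one measured step touches this aryl group, the move from compound 1 to compound 2 with a 3.8-fold higher number from compound 1 to compound 2 (0.57 log units; beyond the scatter), and it concerns fluorine entering where hydrogen stood, not a chlorine changing place. On these data alone, the values of compound 3, which carries a 4-chlorophenyl, sit near those of compound 2, so swapping fluorine for chlorine on this ring shows little effect; how the 3-position behaves is untested. The step is therefore expected to stay within the scatter: a 1.2-fold lower number from compound 2 to compound 4 (0.08 log units; within the scatter). Compound 4 is estimated at 2500 nM, with a range from 1000 nM to 6500 nM.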

Compound 4, half-maximal inhibitory concentration: 900 nM
Beside the measured number, compound 4's estimate is 2.8-fold (0.44 log units) above it; measured number outside the range, below it.
By their numbers in this assay, from the lowest: compounds 1 and 4 (each within the scatter of the next); then compound 2.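

In this assay the swap to 3-chlorophenyl counts for more than the scatter: the record shows a 3.3-fold lower number from compound 2 to compound 4 (0.52 log units; beyond the scatter) and so a halogen on this aryl ring does not always come with a high number. Chlorine on the ring also leaves the plain phenyl level unchanged here, with a 1.1-fold higher number from compound 1 to compound 4 (0.05 log units; within the scatter) as the step, and that step is too small to separate the two compounds. The place of the chlorine therefore matters among these compounds, since compound 4, with its 3-chlorophenyl, gives 900 nM while compound 3, with its 4-chlorophenyl, shows clearly higher numbers: the several entries of compound 3 in this assay, 2800 nM; 2820 nM (2 entries).

These compounds leave open whether fluorine in place of the chlorine of compound 4 would keep the number as low, and whether a larger or quite different group on the ring, such as a methoxy group, an amine or a carboxylic acid, would fit the same picture. They also give no reason why moving the chlorine changes the number, so the shift can be described but not yet explained.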